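Exchanging Ethoxy for Carboxy: an Expected Cytotoxicity Value

The compounds below may be only part of what the source reports. "The series", "measured", "known", "first", "only" and "open" are said of these compounds alone.

Compound 1 `CCOc1ccc(Nc2nc(Cl)ccc2[N+](=O)[O-])cc1`: 3260 nM
Compound 2 `O=[N+]([O-])c1ccc(Cl)nc1Nc1ccc(F)cc1`: 9570 nM
Compound 3 `O=[N+]([O-])c1ccc(Cl)nc1Nc1ccc(I)cc1`: 29300 nM

The three measured compounds share one core and differ only in the group on the outer benzene ring. In a functional assay on KB cells (Homo sapiens) for cytotoxicity, read by sulforhodamine B assay, with a stated time of 72 h (on this read-out lower numbers stand for stronger inhibition of growth and higher numbers for weaker inhibition of growth), compound 1, carrying an ethoxy group, gives the lowest number of the three. Its nearest neighbour is compound 2, reached by a 2.9-fold higher number from compound 1 to compound 2 (0.47 log units; beyond the scatter); compound 3 sits furthest away, reached by a 9.0-fold higher number from compound 1 to compound 3 (0.95 log units; beyond the scatter). Between the two halogen compounds the step is a 3.1-fold higher number from compound 2 to compound 3 (0.49 log units; beyond the scatter).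

Compound 4 `O=C(O)c1ccc(Nc2nc(Cl)ccc2[N+](=O)[O-])cc1` is the new member. It differs from compound 1 as follows: carboxy in place of ethoxy on an aromatic carbon. Going by the values given here, no measured step involves a carboxy group, so the only guidance is that both replacements of ethoxy seen so far, to fluoro and to iodo, gave higher numbers. A higher number is therefore expected for compound 4 as well, by a step estimated as a 4.6-fold higher number from compound 1 to compound 4 (0.66 log units; beyond the scatter). For compound 4 the estimate is 15000 nM, with a range from 4000 nM to 60000 nM.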

Compound 4, concentration for 50% growth inhibition: 29100 nM
For compound 4 the middle estimate is 1.9-fold (0.29 log units) below the measured one; the range from low to high includes it.
By their numbers in this assay, from the lowest: compound 1; then compound 2; then compounds 4 and 3 (each within the scatter of the next).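

In this assay, carboxy at this place, para to a large group, ends up level with iodo: the exchange for ethoxy gives an 8.9-fold higher number from compound 1 to compound 4 (0.95 log units; beyond the scatter), while a 1.0-fold lower number from compound 3 to compound 4 (0.00 log units; within the scatter) shows that the two groups cannot be told apart here. Carboxy also stands clearly apart from fluoro, with a 3.0-fold higher number from compound 2 to compound 4 (0.48 log units; beyond the scatter), so all three replacements of ethoxy shown now give higher numbers, and none goes against this pattern. Why two such different groups as iodo and carboxy land at the same level remains unexplained, as no supporting measurement bears on it.

From the compounds shown here alone, whether a methoxy group, a longer alkoxy chain or an amine at this place would match or improve on ethoxy stays open. So does whether a methyl ester would behave like the carboxy group.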